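A few compounds are considered here, and "the series" means these few. Any claim that something is new, unique, unknown or untested is made for them only; others in the source may bear on it.

Measured in a physicochemical assay for solubility, read by spectrophotometry, in phosphate buffer, with a stated time of 18 h, at pH 7.4; on this read-out higher numbers stand for higher solubility and lower numbers for lower solubility:
- compound 1 `Cc1nn(-c2ccccc2)c2nc(-c3ccc(Cl)cc3)c(C#N)c(-c3ccccc3O)c12`: 3800 nM
- compound 2 `Cc1nn(-c2ccccc2)c2nc(-c3ccc4c(c3)CCCC4)c(C#N)c(-c3ccccc3O)c12`: 13000 nM

Going by the values given here, compound 2 holds the higher of these two numbers, and compound 1 is its only neighbour. Compound 3 `Cc1nn(-c2ccccc2)c2nc(-c3ccc4c(c3)OCCO4)c(C#N)c(-c3ccccc3O)c12` differs from compound 2 by a single exchange: 2,3-dihydro-1,4-benzodioxin-6-yl in place of 1,2,3,4-tetrahydronaphthalen-6-yl on an aromatic carbon, next to the ring nitrogen and ortho to a cyano group (2,3-dihydro-1,4-benzodioxin-6-yl in place of 1,2,3,4-tetrahydronaphthalen-6-yl on an aromatic carbon). Among the compounds with values here, only one measured step bears on this exchange, since it was made on the same aromatic carbon. That step, with 1,2,3,4-tetrahydronaphthalen-6-yl in place of 4-chlorophenyl, is modest: a 3.4-fold higher number from compound 1 to compound 2 (0.53 log units; beyond the scatter). Within the data shown here, no measured compound carries 2,3-dihydro-1,4-benzodioxin-6-yl, so the data give no direction for the new exchange. A shift of similar modest size either way would fit them, but no step beyond the scatter is expected in this assay. The expected change is a 1.1-fold higher number from compound 2 to compound 3 (0.03 log units; within the scatter). The estimate for compound 3 is 14000 nM. Its expected range runs from 5500 nM to 36000 nM.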

Compound 3, solubility: 11000 nM
Compound 3: the middle estimate sits 1.3-fold (0.10 log units) above what was measured; measured number inside the range.
By their numbers in this assay, from the lowest: compound 1; then compounds 3 and 2 (each within the scatter of the next).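

In this assay, putting 2,3-dihydro-1,4-benzodioxin-6-yl in place of 1,2,3,4-tetrahydronaphthalen-6-yl gives a 1.2-fold lower number from compound 2 to compound 3 (0.07 log units; within the scatter) and so the two groups cannot be told apart on this read-out at this position, even though the entering group counts two hydrogen-bond acceptors and the leaving group none. The other new step, a 2.9-fold higher number from compound 1 to compound 3 (0.46 log units; beyond the scatter), lies beyond the scatter, and with a 3.4-fold higher number from compound 1 to compound 2 (0.53 log units; beyond the scatter) it shows that both groups carrying a six-membered non-aromatic ring fused to the aromatic ring stand above 4-chlorophenyl on this aromatic carbon, a pattern that none of these three compounds goes against. Nothing measured here gives a reason for either the gap to compound 1 or the closeness of compound 2 and compound 3.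

From the compounds shown here alone, it remains open whether a 4-methoxyphenyl group, which keeps an ether oxygen without the fused ring, would sit with compound 1 or with the other two, and where a morpholine or another amine would fall on this carbon. Also open, going by these compounds, is whether these steps would hold with a group other than 2-hydroxyphenyl, such as a 2-carboxyphenyl group, elsewhere on the shared core.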